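Side-chain removal at the carbon bearing the amide nitrogen

The source may report more compounds than this note shows. Statements on the series, on what has been measured and on what is new or still open speak of the compounds shown alone.

Compound 1 `O=C(CN(c1nc(Cl)nc2[nH]cnc12)C1CC1)NCC(=O)OCc1ccccc1`: 18% in a functional assay on the whole organism (Tail, strain ICR) with Mus musculus as the target, in the tail flick test, with a stated time of 150 min, at a dose of 25 umol/kg by the oral route; on this read-out lower numbers stand for a weaker effect and higher numbers for a stronger effect at the one dose given
Compound 2 `CC[C@H](C)[C@H](NC(=O)CN(c1nc(Cl)nc2[nH]cnc12)C1CC1)C(=O)O`: 6.71% in this assay
Compound 3 `N=C(N)NCCC[C@H](NC(=O)CN(c1nc(Cl)nc2[nH]cnc12)C1CC1)C(=O)OCc1ccccc1`: 6.12% in this assay

Compound 2 stands second highest of the three numbers; compound 3 lies within the scatter of it, while compound 1 sits beyond the scatter above it. Compound 4 `O=C(O)CNC(=O)CN(c1nc(Cl)nc2[nH]cnc12)C1CC1` carries the change (hydrogen in place of sec-butyl on a saturated chain carbon bound to an amide-type nitrogen and a carbonyl carbon). Within the data shown here, the one measured step at this place is a number 11.9 percentage points lower from compound 1 to compound 3 (beyond the scatter), where a group enters on that carbon and the number falls. Among the measured compounds shown here, compound 4 runs the other way, a group leaving, so a small rise is the nearest reading, though compound 1 and compound 2 also differ elsewhere and no step covers that. For compound 4 a step of a number 5.3 percentage points higher from compound 2 to compound 4 (within the scatter) is expected, giving an estimated 12% with a range of 3% to 24%.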

Compound 4, a percentage reported as activity, at one dose (the size of the read-out at that dose, not a potency): 9.08%
Beside the measured number, compound 4's estimate is 2.9 percentage points above it; low and high end bracket the measured number.
By their numbers in this assay, from the lowest: compounds 3, 2, 4 and 1 (each within the scatter of the next, the first and the last beyond it).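

In this assay hydrogen in place of sec-butyl on this saturated chain carbon, with the carboxylic acid kept, gives a step within the scatter (a number 2.4 percentage points higher from compound 2 to compound 4 (within the scatter)), so this side chain shows no resolved effect in the acid form. Hydrogen in place of benzyl on the oxygen also stays within the scatter (a number 8.9 percentage points lower from compound 1 to compound 4 (within the scatter)), so the benzyl ester and the acid are not separated here. No evidence is available that explains either step.

As far as these compounds go, whether sec-butyl has a resolved effect with the benzyl ester in place remains open. Also open, from the compounds shown here alone, is whether an amine or a longer chain on this carbon would move the number beyond the scatter.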